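The source may hold more compounds than are shown below. What is called first, only, known or untested is meant among the compounds shown, and "the series" means these compounds.

The measured compounds are:

compound 1 `CC(C)n1cnc2c(Nc3cccc(-c4ncccn4)c3)nc(Cl)nc21`, which in an assay on isolated protein (Asteroidea) for inhibition of G2/mitotic-specific cyclin-B (Asterina pectinifera), read by scintillation counting and 33P incorporation, with a stated time of 30 min (on this read-out higher numbers stand for weaker inhibition and lower numbers for stronger inhibition), gives 10000 nM;
compound 2 `CCC[C@@H](O)Nc1nc(Nc2ccc(-c3ncccn3)cc2)c2ncn(C(C)C)c2n1`, which in this assay gives 180 nM;
compound 3 `CCC[C@@H](O)Nc1nc(Nc2ccc(-c3cncnc3)cc2)c2ncn(C(C)C)c2n1`, which in this assay gives 40 nM.

Compound 3 stands lowest of the three numbers in this assay. Its nearest neighbour is compound 2, and the step of a 4.5-fold lower number from compound 2 to compound 3 (0.65 log units; beyond the scatter) carries the change from pyrimidin-2-yl to pyrimidin-5-yl on the aromatic carbon; compound 1, with its chlorine in place of the hydroxyalkylamino side chain, lies far higher.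

Compound 4 `CC(C)C[C@@H](O)Nc1nc(Nc2ccc(-c3cncnc3)cc2)c2ncn(C(C)C)c2n1` differs from compound 3 by methyl in place of hydrogen on a saturated chain carbon bound to two saturated chain carbons. Among the measured compounds shown here, none of the measured steps touches this chain: the one step recorded concerns the pyrimidine, and the gap between compound 1 and compound 2 involves the whole side chain at once. For the measured compounds named here, there is thus no measured step that bears directly on a methyl added to the chain, and with the remainder of compound 3 kept intact, the expectation for compound 4 in this assay is a step no larger than the usual scatter, with no direction favoured: no change at the digits printed from compound 3 to compound 4 (within the scatter). On that basis compound 4 is estimated at 40 nM, with a range from 15 nM to 120 nM.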

Compound 4, half-maximal inhibitory concentration: 17 nM
Estimate against measurement, compound 4: 2.4-fold (0.37 log units) above, within the range that was stated.
By their numbers in this assay, from the lowest: compound 4; then compound 3; then compound 2; then compound 1.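

Among the compounds shown here, the step of a 2.4-fold lower number from compound 3 to compound 4 (0.37 log units; beyond the scatter) in this assay is the first reading on the side chain with everything else held constant, since the earlier single change concerned only the pyrimidine and the gap to compound 1 involves the whole side chain at once. It shows that this saturated chain carbon, bound to two saturated chain carbons, tolerates methyl in place of hydrogen, and that going from 1-hydroxybutyl to 1-hydroxy-3-methylbutyl moves the number downward by a modest step, so that the side chain joins the pyrimidine as a part of these compounds where a single change registers in this read-out. Nothing in the information at hand accounts for this shift.

The compounds shown leave open whether a longer chain, such as 1-hydroxyhexyl, or a cyclohexyl ring at this carbon would lower the number further or raise it again, and whether an amine in place of the hydroxyl would be tolerated. They also leave open whether the same methyl would give a step of similar size on the pyrimidin-2-yl compound 2.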